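Fluoro for Bromo on a Double Bond

A few compounds are considered here, and "the series" means these few. Any claim that something is new, unique, unknown or untested is made for them only; others in the source may bear on it.

In a functional assay on cells (Endothelial cell, Bos taurus) for antiproliferative activity (a lower number here means a stronger inhibitor, a higher number a weaker inhibitor), compound 1 (`COc1ccc(/C(F)=C(/Br)c2cc(OC)c(OC)c(OC)c2)cc1O`) gives > 200000 nM, which is a limit of the assay and not a number. This places compound 1 at the limit of > 200000 nM in this assay, at which 1 of the 3 values shown sits, among the results so far. Compound 2 (`COc1cc(/C=C/c2cc(O)c3ccoc3c2)cc(OC)c1OC`) gives 27000 nM as a number. Compound 3 (`COc1ccc(/C=C(/F)c2cc(OC)c(OC)c(OC)c2)cc1[N+](=O)[O-]`) gives 38400 nM as a number. Compound 4 (`COc1ccc(/C(F)=C(/F)c2cc(OC)c(OC)c(OC)c2)cc1O`) carries fluoro in place of bromo on a double-bonded chain carbon bound to an aromatic carbon and a double-bonded chain carbon. Within the data shown here, no measured pair shows this swap alone, so the expectation is loose. Compound 3 gives 38400 nM with fluoro on its double bond, which points towards a large move to stronger inhibition. The expected size of that move is wide (an at least 3.3-fold lower number from compound 1 to compound 4 (0.52 log units; beyond the scatter)). Compound 4 is estimated at 60000 nM within an expected range from 8000 nM to 180000 nM in this assay.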

Compound 4, half-maximal inhibitory concentration: 4600 nM
Estimate against measurement, compound 4: 13-fold (1.12 log units) above; measured number below the stated range.
By their numbers in this assay, from the lowest: compound 4; then compounds 2 and 3 (each within the scatter of the next). At a limit, above all of these: compound 1.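

Fluoro in place of bromo on this double-bonded chain carbon is the first single change that can be read directly in this assay, and it gives an at least 43-fold lower number from compound 1 to compound 4 (1.63 log units; beyond the scatter). The full size of this step stays unknown, since the value of compound 1 is a limit of the assay and not a number: the limit of > 200000 nM in this assay, at which 1 of the 4 values shown sits.

Even so, exchanging one heavy atom at this position is enough for a large step, which compounds 2 and 3 could not show. Going by these compounds, whether chloro, methyl or an amine on this carbon would give a similar number stays open.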